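This account rests on a few compounds, and the source may have more. Where it says the series, first, only, none or still open, it means among the compounds named here.

Series notes. The shared core of compound 1 `COc1cc2c(Oc3ccc(NC(=O)c4cc(-c5ccc(C(F)(F)F)cc5)ccn4)cc3F)ccnc2cc1OCCCN1CCCCC1` carries a chain ending in a cyclic amine, and the three measured compounds differ only there. In a functional assay on HT-29 cells (Homo sapiens) for cytotoxicity, read by MTT assay, with a stated time of 72 h (on this read-out lower numbers stand for stronger inhibition and higher numbers for weaker inhibition), compound 1 gives 230 nM. Compound 2 `COc1cc2c(Oc3ccc(NC(=O)c4cc(-c5ccc(C(F)(F)F)cc5)ccn4)cc3F)ccnc2cc1OCCCN1CCN(C)CC1` gives 200 nM, and compound 3 `COc1cc2c(Oc3ccc(NC(=O)c4cc(-c5ccc(C(F)(F)F)cc5)ccn4)cc3F)ccnc2cc1OCCCN1CCCC1` gives 720 nM. Among these three numbers compound 1 stands second highest: the step of a 1.2-fold lower number from compound 1 to compound 2 (0.06 log units; within the scatter) is within the scatter, whereas the step of a 3.1-fold higher number from compound 1 to compound 3 (0.50 log units; beyond the scatter) lies beyond it, as does a 3.6-fold higher number from compound 2 to compound 3 (0.56 log units; beyond the scatter).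

Compound 4 `COc1cc2c(Oc3ccc(NC(=O)c4cc(-c5ccc(C)cc5)ccn4)cc3F)ccnc2cc1OCCCN1CCCCC1` has not yet been measured in this assay. It differs from compound 1 by methyl in place of trifluoromethyl on an aromatic carbon. Going by the values given here, none of the measured steps bears on this part of the structure; all three concern the amine at the end of the chain, with the aryl substituent held constant. The series therefore gives no direct reading of the size or direction of such a change, and any expectation rests on compound 1 alone. Compound 4 is expected to come out near 350 nM, with a range from 100 nM to 1200 nM. That estimate means an expected step of a 1.5-fold higher number from compound 1 to compound 4 (0.18 log units; within the scatter), small and uncertain in direction, and a measurement will be needed to settle it.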

Compound 4, half-maximal inhibitory concentration: 340 nM
Estimate against measurement, compound 4: 1.0-fold (0.01 log units) above, and the stated range covers the measured number.
By their numbers in this assay, from the lowest: compounds 2, 1 and 4 (each within the scatter of the next); then compound 3.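

In this assay, going by these compounds alone, the step of a 1.5-fold higher number from compound 1 to compound 4 (0.17 log units; within the scatter) is the first reading away from the amine at the end of the chain, and it lies within the scatter. Trifluoromethyl, with 4 heavy atoms, gives way here to methyl, with 1 heavy atom, on an aromatic carbon para to a large group, with no difference that this read-out can separate from repeat scatter, whereas replacing piperidin-1-yl with pyrrolidin-1-yl at the chain end gives a 3.1-fold higher number from compound 1 to compound 3 (0.50 log units; beyond the scatter) and lies beyond it. Nothing measured here speaks to the reason for this result.

On these data alone, whether the same holds for a chlorine atom, a methoxy group, a nitrile or a carboxylic acid at this place stays open, as does the outcome for a plain phenyl ring without any substituent. Also open, as far as these compounds go, is whether the reading carries over to 4-methylpiperazin-1-yl or pyrrolidin-1-yl at the chain end, as the aryl change is read here with piperidin-1-yl alone.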